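A Second Methoxy Group Added to Compound 1

The source may hold more compounds than are shown below. What is called first, only, known or untested is meant among the compounds shown, and "the series" means these compounds.

Compound 1, `COc1ccc2c(=O)cc(/C=C/c3ccc(OC(F)(F)F)cc3)oc2c1`, was tested in a functional assay on PC-3 cells (Homo sapiens) for antiproliferative activity, read by MTT assay, with a stated time of 12 h; on this read-out higher numbers stand for weaker inhibition and lower numbers for stronger inhibition. In this assay compound 1 gives > 40000 nM, which is a limit of the assay rather than a number. Two related compounds carry a second methoxy group on the shared core and a different substituent on the other aromatic ring: compound 2, `COc1cc(OC)c2c(=O)cc(/C=C/c3ccc(F)cc3)oc2c1`, and compound 3, `COc1cc(OC)c2c(=O)cc(/C=C/c3ccc(Br)cc3)oc2c1`. In this assay compound 2 gives > 40000 nM, again a limit. Compound 3 gives > 40000 nM, also a limit. The single-point change between them, a step that the two limits leave unreadable from compound 2 to compound 3, therefore cannot be sized, because of the limit of > 40000 nM in this assay, at which 3 of the 3 values shown sit.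

Compound 4, `COc1ccc2c(=O)cc(/C=C/c3ccc(OC(F)(F)F)cc3)oc2c1OC`, differs from compound 1 by methoxy in place of hydrogen on an aromatic carbon. Within the data shown here, no measured step bears on this particular change, and every value so far sits at the same limit, so no direction can be read. The expectation is that compound 4 remains near that limit, with an estimated value of 40000 nM and a range from 12000 nM to 120000 nM, an expected step of a number no higher from compound 1 to compound 4 (the limit leaves the size open).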

Compound 4, half-maximal inhibitory concentration: > 40000 nM
Compound 4: no number, only a limit; the forecaster's own chance of this, stated with the estimate: 75%; the middle value sits exactly at the limit.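

Compound 4 gives > 40000 nM, which is a limit of the assay and not a number, so no step from compound 1 to compound 4 can be read: the limit of > 40000 nM in this assay, at which 4 of the 4 values shown sit.

The compounds shown leave open whether this added methoxy, or any other change among them, alters inhibition in this assay.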